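This account rests on a few compounds, and the source may have more. Where it says the series, first, only, none or still open, it means among the compounds named here.

Compound 1 `COc1cccc(Nc2cc3[nH]c(-c4cccc(C(F)(F)F)c4)nc3cn2)n1`: 85000 nM.
Compound 2 `O=C(O)c1ccc(Nc2cc3[nH]c(-c4cccc(C(F)(F)F)c4)nc3cn2)nc1`: < 5000 nM, a limit of the assay.

Among the measured compounds shown here, in a physicochemical assay for solubility, using the shake flask method, measured as kinetic solubility, with a stated time of 20 h, at pH 2 (on this read-out higher numbers stand for higher solubility and lower numbers for lower solubility), compound 1 gives 85000 nM, the only plain number among the two values. Compound 2 reaches (the limit of < 5000 nM in this assay, at which 1 of the 2 values shown sits), so its true solubility is not known. Compound 3 `NC(=O)c1ccc(Nc2cc3[nH]c(-c4cccc(C(F)(F)F)c4)nc3cn2)nc1` differs from compound 1 by 5-carbamoylpyridin-2-yl in place of 6-methoxypyridin-2-yl on a nitrogen on an aromatic ring. For the measured compounds named here, the one measured step at this position, an at least 17-fold lower number from compound 1 to compound 2 (1.23 log units; beyond the scatter), is large and downward, and it bears directly on this change. For compound 3 a smaller downward step is expected, a 4.3-fold lower number from compound 1 to compound 3 (0.63 log units; beyond the scatter). Compound 3 is therefore estimated at 20000 nM, within 5000 nM to 60000 nM.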

Compound 3, solubility: < 5000 nM
Compound 3 gave a limit, no number (the forecaster's own chance of this, stated with the estimate: 25%); middle value at least 4.0-fold (0.60 log units) away from the limit.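

The low read-out in this assay is no longer tied to the carboxylic acid of compound 2: the amide also gives an at least 17-fold lower number from compound 1 to compound 3 (1.23 log units; beyond the scatter). Compound 3 thus sits at a limit of the assay, not at a number: the limit of < 5000 nM in this assay, at which 2 of the 3 values shown sit. The step between compound 2 and compound 3 cannot be read, so the hydroxy and amino groups on the carbonyl carbon cannot be ranked. As far as these compounds go, it remains open whether a group such as an amine or a nitrile in place of the carbamoyl would lift the read-out above that limit.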